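A few compounds are considered here, and "the series" means these few. Any claim that something is new, unique, unknown or untested is made for them only; others in the source may bear on it.

Measured in a functional assay on HCC827 cells (Homo sapiens) for antiproliferative activity, read by CCK-8 assay, with a stated time of 72 h; on this read-out lower numbers stand for stronger inhibition and higher numbers for weaker inhibition:
- compound 1 `C#Cc1cccc(Nc2ncnc3cc(OCCOC(=O)c4ccccc4OC(C)=O)c(OCCOC)cc23)c1`: 100 nM
- compound 2 `C#Cc1cccc(Nc2ncnc3cc(OCCOC(=O)C(C)c4ccc(CC(C)C)cc4)c(OCCOC)cc23)c1`: 400 nM
- compound 3 `C#Cc1cccc(Nc2ncnc3cc(OCCOC(=O)CC4=C(C)/C(=C\c5ccc([S+](C)[O-])cc5)c5ccc(F)cc54)c(OCCOC)cc23)c1`: 300 nM

Compound 2 lies within the scatter of compound 3 and gives a higher number than compound 1. Compound 4 `C#Cc1cccc(Nc2ncnc3cc(OCCOC(=O)C(C)c4ccc5cc(OC)ccc5c4)c(OCCOC)cc23)c1` differs from compound 2 as follows: 6-methoxynaphthalen-2-yl in place of 4-isobutylphenyl on a saturated chain carbon bound to a carbonyl carbon and a saturated chain carbon. Among the measured compounds shown here, no measured step makes this exchange. The nearest evidence is a 4.0-fold higher number from compound 1 to compound 2 (0.60 log units; beyond the scatter), a modest step on a carbonyl carbon that replaces a larger part of the structure. For the measured compounds named here, with only that step as a guide, no change beyond the scatter is expected in this assay, and any direction is tentative. The expected change is a 1.3-fold lower number from compound 2 to compound 4 (0.12 log units; within the scatter). For compound 4 the estimated value is 300 nM, with an expected range of 100 nM to 900 nM.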

Compound 4, half-maximal inhibitory concentration: 100 nM
For compound 4 the middle estimate is 3.0-fold (0.48 log units) above the measured one, within the range that was stated.
By their numbers in this assay, from the lowest: compounds 1 and 4 (each within the scatter of the next); then compounds 3 and 2 (each within the scatter of the next).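

With the rest of the side chain held, the group on a saturated chain carbon bound to a carbonyl carbon and a saturated chain carbon matters in this assay, since 6-methoxynaphthalen-2-yl in place of 4-isobutylphenyl gives a 4.0-fold lower number from compound 2 to compound 4 (0.60 log units; beyond the scatter), a step beyond the scatter. The earlier compounds shown here offered no exchange at this place. No measurement at hand bears on the reason for this step.

Still open, from the compounds shown here alone, is whether the methoxy group or the second aromatic ring carries the step. An unsubstituted naphthalen-2-yl or a 6-hydroxynaphthalen-2-yl at this place would help separate the two.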